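Aryl amine variants on the shared core: compound 4

The source may hold more compounds than are shown below. What is called first, only, known or untested is meant among the compounds shown, and "the series" means these compounds.

Measured so far:
compound 1 `Cc1ccc(NC2=CC(=O)c3c(nc4n3[C@H]3OC[C@@H](O)[C@H]3OC4)C2=O)cc1C` — 4950 nM
compound 2 `O=C1C=C(N2CCCCC2)C(=O)c2c1nc1n2[C@H]2OC[C@@H](O)[C@H]2OC1` — a limit only, > 8000 nM
compound 3 `O=C1C=C(Nc2ccc(Br)cc2)C(=O)c2c1nc1n2[C@H]2OC[C@@H](O)[C@H]2OC1` — 2580 nM

In a functional assay on MCF7 cells (Homo sapiens) for inhibition, read by sulforhodamine B assay (on this read-out higher numbers stand for weaker inhibition and lower numbers for stronger inhibition), compound 1 gives 4950 nM and stands highest of the two numbers. The nearest is compound 3 at 2580 nM, a gap within the scatter, so the two are not told apart. Compound 2 returns only a limit, > 8000 nM. Within the data shown here, the single measured step is an at least 3.1-fold lower number from compound 2 to compound 3 (0.49 log units; beyond the scatter); its size is bounded by the limit of > 8000 nM in this assay, at which 1 of the 3 values shown sits, the limit at which compound 2 sits.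

Compound 4 `CCc1ccc(NC2=CC(=O)c3c(nc4n3[C@H]3OC[C@@H](O)[C@H]3OC4)C2=O)cc1` is the next entry. It differs from compound 1 by 4-ethylphenyl in place of 3,4-dimethylphenyl on an amine nitrogen. Among the measured compounds shown here, the one measured step swaps piperidin-1-yl for an aryl amine and does not reach the aryl-to-aryl exchange here. What bears on it is that compound 1 and compound 3, both aryl amines with different substituents on the phenyl, sit within the scatter of each other. For compound 4 the expectation is therefore no step beyond the scatter, a 1.2-fold lower number from compound 1 to compound 4 (0.07 log units; within the scatter). Compound 4 is estimated at 4200 nM, with a range from 1800 nM to 9000 nM.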

Compound 4, half-maximal inhibitory concentration: 8990 nM
Estimate against measurement, compound 4: 2.1-fold (0.33 log units) below; the range from low to high includes it.
By their numbers in this assay, from the lowest: compounds 3, 1 and 4 (each within the scatter of the next, the first and the last beyond it).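

In this assay the exchange on the amine nitrogen gives a 1.8-fold higher number from compound 1 to compound 4 (0.26 log units; within the scatter), so 3,4-dimethylphenyl and 4-ethylphenyl, which have the same heavy-atom count, are not told apart at this position. The earlier step showed only the exchange of piperidin-1-yl for an aryl amine, whereas this pair tests two aryl groups against each other and gives no sign that rearranging these carbon atoms on the phenyl ring matters in this assay. A spread among the aryl amines appears only between the two ends of the series, with compound 3 at 2580 nM and compound 4 at 8990 nM lying beyond the scatter of each other, while compound 1 lies within the scatter of both.

Going by these compounds, compound 2 gives > 8000 nM, which is a limit of the assay, so its standing against compound 4 stays open: the limit of > 8000 nM in this assay, at which 1 of the 4 values shown sits. Also open, on these data alone, is how 4-chlorophenyl, 4-methoxyphenyl or a longer alkyl chain on the amine nitrogen would read against these aryl amines.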